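Lengthening the Aromatic Side Chain in a Urea Inhibitor

The source may report more compounds than this note shows. Statements on the series, on what has been measured and on what is new or still open speak of the compounds shown alone.

Compound 1 `CCCc1ccc(NC(=O)Nc2c(C(C)C)cccc2C(C)C)cc1` is a urea that carries a short propyl chain on one of its aromatic rings. In an assay on isolated protein for inhibition of acyl-CoA:cholesterol acyltransferase (Oryctolagus cuniculus) (on this read-out higher numbers stand for weaker inhibition and lower numbers for stronger inhibition), compound 1 gives 38 nM. Of the two compounds measured, compound 1 has the highest number; the nearest is compound 2 `CCCCCCCCCCCCc1ccc(NC(=O)Nc2c(C(C)C)cccc2C(C)C)cc1`, which in this assay gives 15 nM. Compound 3 `CCCCCCCCCCc1ccc(NC(=O)Nc2c(C(C)C)cccc2C(C)C)cc1` is not yet measured and differs from compound 1 by heptyl in place of hydrogen on a saturated chain carbon, three bonds along the chain from an aromatic carbon. Within the data shown here, the single measured step that speaks to this change is the one in which a longer nonyl group entered at the same place: a 2.5-fold lower number from compound 1 to compound 2 (0.40 log units; beyond the scatter). Since the heptyl extension in compound 3 falls between the propyl of compound 1 and the chain of compound 2, a step in the same direction and of similar or slightly smaller size is expected: a 1.9-fold lower number from compound 1 to compound 3 (0.28 log units; within the scatter). In this assay compound 3 is therefore estimated to give about 20 nM, with a likely range from 9 nM to 45 nM.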

Compound 3, half-maximal inhibitory concentration: 13 nM
Estimate against measurement, compound 3: 1.5-fold (0.19 log units) above; measured number inside the range.
By their numbers in this assay, from the lowest: compounds 3 and 2 (each within the scatter of the next); then compound 1.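

Heptyl at this place already brings a 2.9-fold lower number from compound 1 to compound 3 (0.47 log units; beyond the scatter) in this assay and so a chain shorter than that of compound 2 is enough for a step beyond the scatter. Hydrogen in place of ethyl on a saturated chain carbon gives a 1.2-fold lower number from compound 2 to compound 3 (0.06 log units; within the scatter) and so the two long chains cannot be told apart on this read-out. Nothing measured here explains why the longer chains give lower numbers than the propyl chain of compound 1.

Still open, from the compounds shown here alone, is how a pentyl or hexyl chain would read, which would show how short the chain can be and still keep this step. Also open, going by these compounds, is whether a longer chain, or one carrying a carboxylic acid or an amine, would keep the number or change it.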